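From 3-hydroxyphenyl to phenyl: what to expect

This account rests on a few compounds, and the source may have more. Where it says the series, first, only, none or still open, it means among the compounds named here.

The values in a functional assay on HCT-116 cells (Homo sapiens) for inhibition, read by MTT assay, with a stated time of 48 h (a lower number here means a stronger inhibitor, a higher number a weaker inhibitor), so far are these:

compound 1 `COc1cc(-c2cc(-c3ccc(C)cc3)nc(-c3ccccc3)n2)cc(OC)c1OC` gives 15700 nM
compound 2 `COc1cc(-c2cc(-c3cccc(O)c3)nc(-c3ccccc3)n2)cc(OC)c1OC` gives 20400 nM

Compound 2 can be compared only with compound 1, and their two values lie within the scatter of each other, so neither can be ranked above the other. The next molecule, compound 3 `COc1cc(-c2cc(-c3ccccc3)nc(-c3ccccc3)n2)cc(OC)c1OC`, has not yet been measured. It carries hydrogen in place of hydroxy on an aromatic carbon and so turns 3-hydroxyphenyl into phenyl. Among the compounds with values here, the only measured step of a 1.3-fold higher number from compound 1 to compound 2 (0.11 log units; within the scatter) concerns this same group, placing 3-hydroxyphenyl where 4-methylphenyl stood, and it stayed within the scatter. Within the data shown here, a single step is thin evidence, and no measured compound yet carries plain phenyl at this place. Even so, the expected step of a 1.1-fold lower number from compound 2 to compound 3 (0.05 log units; within the scatter) in this assay is no larger than the scatter. Compound 3 is estimated at 18000 nM with an expected range of 9000 nM to 36000 nM in this measurement.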

Compound 3, half-maximal inhibitory concentration: 9950 nM
The estimate for compound 3 lay 1.8-fold (0.26 log units) above the measured number; low and high end bracket the measured number.
By their numbers in this assay, from the lowest: compounds 3, 1 and 2 (each within the scatter of the next, the first and the last beyond it).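

In this assay, within the data shown here, taking the hydroxy group off the ring gives a 2.1-fold lower number from compound 2 to compound 3 (0.31 log units; beyond the scatter) and so produces the first step in this short series that passes the usual scatter, though only modestly. Taking the methyl group off gives a 1.6-fold lower number from compound 1 to compound 3 (0.20 log units; within the scatter) and stays within the scatter, so compound 1 and compound 3 cannot be ranked against each other, and the plain phenyl ring holds up without either group. The numbers tie the lower value to the loss of the hydroxy group in this one pair of compounds, but nothing at hand explains that link.

The compounds shown leave open how an amine, a carboxylic acid or a longer chain such as propyl would behave on this ring. They also leave open whether moving the hydroxy group to another carbon of the ring, or replacing it with methoxy, would bring a step of similar size.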